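The compounds below may be only part of what the source reports. "The series", "measured", "known", "first", "only" and "open" are said of these compounds alone.

Compound 1, `Cc1nc(N)sc1CCCN/C(N)=N/C(=O)NC(C)c1ccccc1F`, reaches 0.93 in a functional assay on Right cardiac atrium for agonist activity at histamine H2 receptor (Cavia porcellus), with a stated time of 30 min, in the presence of a further agent that is not named here; a higher number here means a larger maximal response, a lower number a smaller maximal response. Compound 2, `Cc1nc(N)sc1CCCN/C(N)=N/C(=O)NC(C)c1ccc(OC(F)(F)F)cc1`, reaches 0.61 in this assay; compound 2 stands lowest of the two numbers measured, and compound 1 is higher beyond the scatter. Compound 3, `Cc1nc(N)sc1CCCN/C(N)=N/C(=O)NC(C)c1ccc(F)cc1`, is not yet measured. It differs from compound 2 in one place: fluoro in place of trifluoromethoxy on an aromatic carbon. Compound 1 carries a fluoro on its ring and gives 0.93, so the step from compound 2 to compound 3 is expected to be a rise beyond the scatter, a number 0.24 higher from compound 2 to compound 3 (beyond the scatter). Compound 3 is estimated to reach 0.85, within 0.7 to 1.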

Compound 3, intrinsic activity: the largest response reached, as a fraction of the reference agonist's: 0.92
Compound 3: the middle estimate sits 0.070 below what was measured; low and high end bracket the measured number.
By their numbers in this assay, from the lowest: compound 2; then compounds 3 and 1 (each within the scatter of the next).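

In this assay the aromatic carbon para to a large group responds strongly to its substituent: fluoro in place of trifluoromethoxy gives a number 0.31 higher from compound 2 to compound 3 (beyond the scatter) and ties the lower maximal response of compound 2 to trifluoromethoxy at this carbon. With 4-fluorophenyl in place of 2-fluorophenyl, the series shows a number 0.010 lower from compound 1 to compound 3 (within the scatter) and the two fluoro placements cannot be told apart. Nothing available explains either step. Still open, going by these compounds, is whether chloro, methoxy or methyl at this carbon keeps the response of compound 3 or falls towards that of compound 2.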